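Swapping the indolylethyl arm for phenethyl on a triazole series

The compounds below may be only part of what the source reports. "The series", "measured", "known", "first", "only" and "open" are said of these compounds alone.

Measured compounds:
compound 1, `COc1ccc(Cn2c(CCc3ccccc3)nnc2[C@H](NC(=O)C(C)(C)N)c2c[nH]c3ccccc23)c(OC)c1`, 60 nM
compound 2, `COc1ccc(Cn2c(CCc3c[nH]c4ccccc34)nnc2[C@H](NC(=O)c2ccccn2)c2c[nH]c3ccccc23)c(OC)c1`, 1.8 nM

Of the compounds shown here, two have been measured in an in vitro assay on LLC-PK1 cells for displacement of a labelled ligand from growth hormone secretagogue receptor type 1 (Homo sapiens); a lower number here means a stronger inhibitor, a higher number a weaker inhibitor. Compound 1 gives 60 nM, while compound 2 gives 1.8 nM, the lower of the two numbers by a margin that lies beyond the scatter. Compound 2 thus stands as the stronger binder of the pair; compound 1 differs from it in two places at once, so those two values alone do not separate the contributions.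

Compound 3, `COc1ccc(Cn2c(CCc3ccccc3)nnc2[C@H](NC(=O)c2ccccn2)c2c[nH]c3ccccc23)c(OC)c1`, keeps the amide of compound 2 and changes only the side arm: phenyl in place of 1H-indol-3-yl on a saturated chain carbon, two bonds along the chain from an aromatic carbon. Going by the values given here, no measured pair isolates this change. The account expects a moderate step toward a higher number, likely beyond the scatter, namely a 3.3-fold higher number from compound 2 to compound 3 (0.52 log units; beyond the scatter). That expected step would still fall well short of the gap seen between compound 1 and compound 2. Compound 3 is therefore estimated at 6 nM, within a range from 2 nM to 20 nM.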

Compound 3, half-maximal inhibitory concentration: 1.1 nM
For compound 3 the middle estimate is 5.5-fold (0.74 log units) above the measured one, outside the stated range (below it).
By their numbers in this assay, from the lowest: compounds 3 and 2 (each within the scatter of the next); then compound 1.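

In this assay, phenyl in place of 1H-indol-3-yl on a saturated chain carbon, two bonds along the chain from an aromatic carbon, gives a 1.6-fold lower number from compound 2 to compound 3 (0.21 log units; within the scatter), so the two groups cannot be told apart at this position, even though the hydrogen-bond donor counted in 1H-indol-3-yl is absent from phenyl. The amide change can now be read on its own as well: pyridin-2-yl in place of 1-amino-1-methylethyl on a carbonyl carbon gives a 55-fold lower number from compound 1 to compound 3 (1.74 log units; beyond the scatter), a large step, unlike the side-arm change. Nothing measured here accounts for either step.

From the compounds shown here alone, it remains open whether the side arm would tolerate a saturated cyclohexyl ring in place of phenyl, or a longer chain. Going by these compounds, it is equally open whether an amine on the pyridine ring would keep the value of compound 3.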